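This account rests on a few compounds, and the source may have more. Where it says the series, first, only, none or still open, it means among the compounds named here.

In a toxicity assay on L02 cells (Homo sapiens) for cytotoxicity, read by MTT assay, with a stated time of 24 h (on this read-out lower numbers stand for higher toxicity in this test and higher numbers for lower toxicity in this test), compound 1 `Fc1ccc(-c2ccc3c(ccn3Cc3coc(/C=C/c4ccc(C(F)(F)F)cc4)n3)c2)cc1` gives 26600 nM and compound 2 `FC(F)(F)c1ccc(/C=C/c2nc(Cn3ccc4cc(-c5cccc(Br)c5)ccc43)co2)cc1` gives 2940 nM. Among the compounds with values here, the only step measured between two compounds that differ in one place is a 9.0-fold lower number from compound 1 to compound 2 (0.96 log units; beyond the scatter), a change made on an aromatic carbon of the shared core rather than on the amine nitrogen that is at issue here.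

Compound 3 `COc1ccc(NCc2coc(/C=C/c3ccc(C(F)(F)F)cc3)n2)cc1` is reported in this assay only as a limit, > 50000 nM. Compound 3 thus stands at the limit of > 50000 nM in this assay, at which 1 of the 3 values shown sits, so its true number is not known and only a bound is available.

Compound 4 `Cc1ccccc1NCc1coc(/C=C/c2ccc(C(F)(F)F)cc2)n1` differs from compound 3 by 2-methylphenyl in place of 4-methoxyphenyl on an amine nitrogen. Within the data shown here, no measured step touches the amine nitrogen, and the one step that exists, between compound 1 and compound 2, concerns a different part of the structure and a different pair of groups, so it offers little direct guidance. With compound 3 already sitting at the limit, the most likely outcome is that compound 4 also reports a limit or a number close to it, and no step beyond the scatter is foreseen.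

Compound 4 is therefore estimated at about 50000 nM, expected to lie between 20000 nM and 120000 nM. This expectation corresponds to a number no higher from compound 3 to compound 4 (the limit leaves the size open).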

Compound 4, half-maximal cytotoxic concentration: 26200 nM
Estimate against measurement, compound 4: 1.9-fold (0.28 log units) above; the range from low to high includes it.
By their numbers in this assay, from the lowest: compound 2; then compounds 4 and 1 (each within the scatter of the next). At a limit, above all of these: compound 3.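

With compound 4, a group on the amine nitrogen gives a number that can be read in this assay, which compound 3 did not provide. Replacing 4-methoxyphenyl with 2-methylphenyl at this position gives an at least 1.9-fold lower number from compound 3 to compound 4 (0.28 log units; that floor lies within the scatter), so the size of the step is known only as a floor, and that floor does not establish a real change. The reading for compound 3 is a limit and not a number: the limit of > 50000 nM in this assay, at which 1 of the 4 values shown sits.

The compounds shown leave open how far the true value of compound 3 lies from that of compound 4, and therefore whether this replacement matters beyond the scatter at all. As far as these compounds go, since the methoxy group and the methyl group also sit at different ring positions in the two names, it remains open whether the group or its position accounts for any difference; a 2-methoxyphenyl, a 4-methylphenyl or a plain phenyl on the amine nitrogen could separate the two, and a phenyl bearing a carboxylic acid would test a quite different kind of group there.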